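The source may hold more compounds than are shown below. What is called first, only, known or untested is meant among the compounds shown, and "the series" means these compounds.

Measured compounds in the series:

compound 1 `CN(c1ccc2cc(NC(=O)CCc3ccc(C(F)(F)F)cc3)ccc2n1)C1CCCCC1` — 18 nM
compound 2 `CCCN(CCC)c1ccc2cc(NC(=O)CCc3ccc(C(F)(F)F)cc3)ccc2n1` — 490 nM
compound 3 `CC(C)C(=O)NC1CCN(c2ccc3cc(NC(=O)CCc4ccc(C(F)(F)F)cc4)ccc3n2)C1` — 1 nM

All three share one core and one amide side chain and differ only in the amino substituent on the aromatic carbon. In an assay on isolated protein for displacement of a labelled ligand from melanin-concentrating hormone receptor 1 (Homo sapiens) (on this read-out higher numbers stand for weaker inhibition and lower numbers for stronger inhibition), compound 3 gives the lowest number of the set; its nearest neighbour is compound 1, and the step of an 18-fold lower number from compound 1 to compound 3 (1.26 log units; beyond the scatter) is large, while a 490-fold lower number from compound 2 to compound 3 (2.69 log units; beyond the scatter) is larger still. Within compound 1 and compound 2 the step of a 27-fold higher number from compound 1 to compound 2 (1.43 log units; beyond the scatter) shows that the amino substituent alone moves the numbers strongly.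

Compound 4 `CC(=O)NC1CCN(c2ccc3cc(NC(=O)CCc4ccc(C(F)(F)F)cc4)ccc3n2)C1` keeps the pyrrolidine and the amide nitrogen of compound 3 and changes only the acyl group: methyl in place of isopropyl on a carbonyl carbon. Going by the values given here, no measured step touches this position; every step recorded so far concerns the amino substituent, which compound 4 leaves as in compound 3. The change is small in what it counts, and the part that carries the large steps is unchanged, so the expectation is a step near or within the scatter, if anything toward a somewhat higher number, that is a 2.0-fold higher number from compound 3 to compound 4 (0.30 log units; within the scatter). For compound 4 in this assay the estimate is 2 nM, with a range from 0.7 nM to 6 nM.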

Compound 4, half-maximal inhibitory concentration: 5 nM
For compound 4 the middle estimate is 2.5-fold (0.40 log units) below the measured one; measured number inside the range.
By their numbers in this assay, from the lowest: compound 3; then compound 4; then compound 1; then compound 2.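

The acyl group is not a silent position: in this assay, methyl in place of isopropyl on a carbonyl carbon gives a 5.0-fold higher number from compound 3 to compound 4 (0.70 log units; beyond the scatter) as a modest step beyond the scatter, so the amino substituent is not the only part of the series that moves the numbers. The 3-acetamidopyrrolidin-1-yl group still keeps a clear lead over the other two amino substituents, with a 98-fold lower number from compound 2 to compound 4 (1.99 log units; beyond the scatter) against dipropylamino and a 3.6-fold lower number from compound 1 to compound 4 (0.56 log units; beyond the scatter) against cyclohexyl(methyl)amino, both beyond the scatter, so the shorter acyl group gives back only part of what the 3-((isopropylcarbonyl)amino)pyrrolidin-1-yl group gained. No supporting data are available to account for the step at the acyl group.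

With only acetyl and isopropylcarbonyl in hand, a single step cannot show whether the numbers follow the carbon count of the acyl group, and a propanoyl, cyclopropylcarbonyl or tert-butylcarbonyl group would be needed to test that. Also open, on these data alone, is whether the amide itself is needed at this position, which a urea, a sulfonamide or a simple amine in its place would address.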